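The source may report more compounds than this note shows. Statements on the series, on what has been measured and on what is new or still open speak of the compounds shown alone.

Compound 2 `CNS(=O)(=O)c1cn(Cc2nc3cc(Cl)ccc3n2CCCS(C)(=O)=O)c2ccccc12` was tested in an ADME assay on HEp-2 cells (Homo sapiens) for cytotoxicity, with a stated time of 4 days; a higher number here means that more compound is tolerated, a lower number that less compound is tolerated. For compound 2 the result is a limit of the assay rather than a number, recorded as > 100000 nM. Two other compounds sharing the same core were measured alongside. Compound 1 `CS(=O)(=O)CCn1c(Cn2cc(S(C)(=O)=O)c3ccccc32)nc2cc(Cl)ccc21` also reached only a limit, > 100000 nM. Compound 3 `CS(=O)(=O)CCCn1c(Cn2nc(S(C)(=O)=O)c3ccncc32)nc2cc(Cl)ccc21` likewise gave a limit, > 100000 nM. Compound 2 therefore stands exactly where every other measured compound stands: at the limit of > 100000 nM in this assay, at which 3 of the 3 values shown sit, with no number to set it apart. Among the compounds with values here, no step between measured compounds can be read from these data; the three limits show only that none of them was tolerated less than the top of the tested range.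

Compound 4 `CC(C)S(=O)(=O)c1cn(Cc2nc3cc(Cl)ccc3n2CCCS(C)(=O)=O)c2ccccc12` differs from compound 2 by isopropyl in place of methylamino on a sulfonyl sulfur, that is, methylsulfamoyl becomes isopropylsulfonyl. Since every measured compound sits at the same limit, the step from compound 2 to compound 4 in this assay is expected to be none beyond the scatter, a number no higher from compound 2 to compound 4 (the limit leaves the size open). Compound 4 is estimated at 100000 nM, within a range from 40000 nM to 300000 nM, and most likely it too will be reported only as a limit.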

Compound 4, half-maximal cytotoxic concentration: > 100000 nM
Compound 4: only a limit was reported (the forecaster's own chance of this, stated with the estimate: 85%); the middle value lies on the limit itself.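

In this assay, within the data shown here, compound 4, like compound 2, gives only a limit, so no step between them can be read. Both stand with the others at one value: the limit of > 100000 nM in this assay, at which 4 of the 4 values shown sit. The compounds shown leave open how far any of them lies beyond that limit.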